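This account rests on a few compounds, and the source may have more. Where it says the series, first, only, none or still open, it means among the compounds named here.

Compound 2 `C#CCO/N=C/c1c(-c2ccc(F)cc2)nc2c(C)cccn12` gives 100 mg/kg in a functional assay on the whole organism (strain NMRI) with Mus musculus as the target, with a stated time of 4 h (a higher number here means that more compound is needed for the effect, a lower number that less compound is needed), the highest of the three measured numbers. Compound 1 `C#CCO/N=C/c1c(-c2ccc(C)cc2)nc2c(C)cccn12` gives 20 mg/kg, and compound 3 `Cc1cccn2c(/C=N/O)c(-c3ccc(F)cc3)nc12` gives 40 mg/kg. The step of a 5.0-fold higher number from compound 1 to compound 2 (0.70 log units; beyond the scatter) came from fluoro in place of methyl on an aromatic carbon, and the step of a 2.5-fold lower number from compound 2 to compound 3 (0.40 log units; beyond the scatter) from hydrogen in place of propargyl on an oxygen. Compound 4 `C#CCO/N=C/c1c(-c2ccccc2)nc2c(C)cccn12` differs from compound 2 in one place: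
hydrogen in place of fluoro on an aromatic carbon
Only the first of those steps touches the same aromatic carbon, and it shows that the group there matters. Taking the fluoro away is expected to return the number part of the way toward compound 1. A modest lowering a 2.5-fold lower number from compound 2 to compound 4 (0.40 log units; beyond the scatter) is therefore expected. Compound 4 is estimated at 40 mg/kg, within 15 mg/kg to 120 mg/kg.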

Compound 4, minimum effective dose: 100 mg/kg
Compound 4: the middle estimate sits 2.5-fold (0.40 log units) below what was measured; low and high end bracket the measured number.
By their numbers in this assay, from the lowest: compounds 1 and 3 (each within the scatter of the next); then compounds 2 and 4 (each within the scatter of the next).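

In this assay, the change gave no change at the digits printed from compound 2 to compound 4 (within the scatter), so fluoro and hydrogen on this aromatic carbon cannot be told apart. Within the data shown here, only methyl separates from them, with hydrogen in its place giving a 5.0-fold higher number from compound 1 to compound 4 (0.70 log units; beyond the scatter); the earlier compounds showed that the group here matters, but not that the difference rests with the methyl alone. No measurement at hand gives a reason for this. On these data alone, whether methoxy, ethyl or an amine on this carbon would side with compound 1 or with compounds 2 and 4 remains open. Also open, as far as these compounds go, is whether the same pattern holds with hydrogen in place of propargyl on the oxygen.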